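Dimethylamino to Diethylamino on the Basic Side Chain

A few compounds are considered here, and "the series" means these few. Any claim that something is new, unique, unknown or untested is made for them only; others in the source may bear on it.

Compound 1 `CN(C)CCn1c(N)c(-c2nc3ccccc3[nH]2)c2nc(C#N)c(C#N)nc21` and compound 2 `CCN(CC)CCn1c(N)c(-c2nc3ccccc3[nH]2)c2nc(C#N)c(C#N)nc21` share one core. In a functional assay on cells (Homo sapiens) for antiproliferative activity, read by MTT assay, with a stated time of 48 h (on this read-out higher numbers stand for weaker inhibition and lower numbers for stronger inhibition), compound 1 gives 43500 nM and compound 2 gives 25400 nM. The change diethylamino in place of dimethylamino on a saturated chain carbon, two bonds along the chain from an aromatic nitrogen made the step of a 1.7-fold lower number from compound 1 to compound 2 (0.23 log units; within the scatter).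

Compound 3 `CN(C)CCCCn1c(N)c(-c2nc3ccccc3n2C)c2nc(C#N)c(C#N)nc21` carries a different core; the difference between the two cores is not broken down here. In this assay compound 3 gives 1790 nM, the lowest of the three numbers, with compound 2 and compound 1 both beyond the scatter above it.

Compound 4 `CCN(CC)CCCCn1c(N)c(-c2nc3ccccc3n2C)c2nc(C#N)c(C#N)nc21` is not yet measured. It differs from compound 3 by diethylamino in place of dimethylamino on a saturated chain carbon, four bonds along the chain from an aromatic nitrogen. This is the same kind of change as before, but at another place: earlier the group sat on a saturated chain carbon two bonds along the chain from an aromatic nitrogen, here it sits four bonds along the chain from an aromatic nitrogen. The earlier step of a 1.7-fold lower number from compound 1 to compound 2 (0.23 log units; within the scatter) stayed within the scatter. On that footing a step of a 1.4-fold lower number from compound 3 to compound 4 (0.14 log units; within the scatter) is expected here. Compound 4 is expected to give 1300 nM in this assay, within a range from 600 nM to 3500 nM.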

Compound 4, half-maximal inhibitory concentration: 2890 nM
The estimate for compound 4 lay 2.2-fold (0.35 log units) below the measured number, within the range that was stated.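

In this assay, among these compounds, diethylamino in place of dimethylamino gives a 1.6-fold higher number from compound 3 to compound 4 (0.21 log units; within the scatter) on the core of compound 3, so on each core the single step stays within the scatter, yet the two steps run in opposite directions and differ when set side by side: the same change on two cores in this assay, a 1.7-fold lower number (0.23 log units; within the scatter) from compound 1 to compound 2 and a 1.6-fold higher number (0.21 log units; within the scatter) from compound 3 to compound 4, 2.8-fold (0.44 log units) apart, beyond the scatter of two such steps. Carrying the change from one core to another therefore cannot be treated as a fixed shift in this series. The gap is not shown to come from the core alone, since the group sits two bonds along the chain from an aromatic nitrogen in one pair and four bonds along in the other.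

Still open, as far as these compounds go, is how a cyclic amine such as pyrrolidine or morpholine would read on either core. Also open, from the compounds shown here alone, is how the change would read on each core with the other chain.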